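The source may report more compounds than this note shows. Statements on the series, on what has been measured and on what is new or still open speak of the compounds shown alone.

Going by the values given here, in an ADME assay on microsomes from liver (Mus musculus) for metabolic stability (a higher number here means that the compound lasts longer, a lower number that the compound disappears faster), compound 1 `CC(C)C(Nc1nnc[nH]1)c1ccc(-c2ccc3cccc(F)c3c2)[nH]c1=O` gives 2.42 h, the only exact number so far. Compound 2 `CCn1ncc2c(F)cc(-c3ccc(C(CC)(CC)c4nnc[nH]4)c(=O)[nH]3)cc21` reads > 3 h, which is a limit of the assay. Compound 3 `CCn1ncc2c(F)cc(-c3ccc(C(CC)(CC)c4nnc(C)[nH]4)c(=O)[nH]3)cc21` reads > 3 h, also a limit. Among the compounds with values here, the other compounds therefore offer only (the limit of > 3 h in this assay, at which 2 of the 3 values shown sit), and the single measured step, a step that the two limits leave unreadable from compound 2 to compound 3, has no readable size and concerns a different change.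

Compound 4 `CC(C)C(c1cnc(N)s1)c1ccc(-c2ccc3cccc(F)c3c2)[nH]c1=O` carries 2-amino-1,3-thiazol-5-yl in place of (4H-1,2,4-triazol-3-yl)amino, one five-membered aromatic ring exchanged for another: 2-amino-1,3-thiazol-5-yl in place of (4H-1,2,4-triazol-3-yl)amino on a saturated chain carbon bound to an aromatic carbon and a saturated chain carbon. Within the data shown here, no measured step covers this exchange, so the best guide is compound 1 at 2.42 h. The expected 1.3-fold lower number from compound 1 to compound 4 (0.11 log units; within the scatter) has no clear direction and stays within the usual scatter. For compound 4, the estimate is 1.9 h, with a range of 0.8 h to 4 h.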

Compound 4, half-life: 0.08 h
Beside the measured number, compound 4's estimate is 24-fold (1.38 log units) above it; the whole stated range lies above it.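

In this assay, the group on this saturated chain carbon turns out to matter greatly: 2-amino-1,3-thiazol-5-yl in place of (4H-1,2,4-triazol-3-yl)amino gives a 30-fold lower number from compound 1 to compound 4 (1.48 log units; beyond the scatter). Going by these compounds alone, this is the first step of readable size, as the step between the two compounds at the assay limit cannot be read, and it shows that these two five-membered aromatic rings are not interchangeable here. No measurement shown accounts for the size of this step.

As far as these compounds go, whether the drop follows the thiazole ring itself or its amino group stays open. A plain 1,3-thiazol-5-yl on the same carbon would separate the two.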